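Trifluoromethoxy for trifluoromethyl on the shared core

The source may report more compounds than this note shows. Statements on the series, on what has been measured and on what is new or still open speak of the compounds shown alone.

Measured so far:
compound 1 `Oc1ccccc1-c1cc(-c2cccc(C(F)(F)F)c2)cc(-c2ccccc2O)n1`: > 50000 nM
compound 2 `Oc1cccc(-c2cc(-c3cccc(C(F)(F)F)c3)cc(-c3ccccc3O)n2)c1`: 6460 nM

In a functional assay on HCT-15 cells (Homo sapiens) for inhibition (a lower number here means a stronger inhibitor, a higher number a weaker inhibitor), compound 1 gives only a limit, > 50000 nM. In this assay compound 2 gives 6460 nM, the only number shown, with an at least 7.7-fold lower number from compound 1 to compound 2 (0.88 log units; beyond the scatter).

Compound 3 `Oc1cccc(-c2cc(-c3cccc(OC(F)(F)F)c3)cc(-c3ccccc3O)n2)c1` carries trifluoromethoxy in place of trifluoromethyl on an aromatic carbon. Among the compounds with values here, the one measured step concerns the hydroxyphenyl groups and does not bear on this change. Within the data shown here, no measured step bears on it, so no step beyond the scatter is expected in this assay, in either direction. Compound 3 is therefore estimated at 6000 nM, range 2500 nM to 15000 nM, an expected step of a 1.1-fold lower number from compound 2 to compound 3 (0.03 log units; within the scatter).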

Compound 3, half-maximal inhibitory concentration: 2740 nM
Compound 3: middle estimate off by 2.2-fold (0.34 log units), on the high side, and the stated range covers the measured number.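

The group on this aromatic carbon is not a silent position in this assay: trifluoromethoxy in place of trifluoromethyl gives a 2.4-fold lower number from compound 2 to compound 3 (0.37 log units; beyond the scatter). Within the data shown here, the earlier step concerned only the hydroxyphenyl groups, so this is the first sign that this second place in the shared core also moves the number. Nothing measured here accounts for the step.

Still open, on these data alone, is whether a nitrile, an amine or a longer alkoxy chain on this carbon would go further. Also open, as far as these compounds go, is whether the gain carries over to the 2-hydroxyphenyl arrangement of compound 1.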